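Adding Chloro to a Butyl-Alkynyl Compound

A few compounds are considered here, and "the series" means these few. Any claim that something is new, unique, unknown or untested is made for them only; others in the source may bear on it.

Measured so far in an ADME assay for permeability, using PAMPA, at pH 4; on this read-out higher numbers stand for higher permeability and lower numbers for lower permeability:
Compound 1 `Cc1[nH]c2ccc(Cl)cc2c(=O)c1Br` gives 84.5 10^-6 cm/s
Compound 2 `CCCCC#Cc1c(C)[nH]c2ccccc2c1=O` gives 500 10^-6 cm/s

Compound 2 holds the higher of the two numbers, and its gap to compound 1 lies beyond the scatter. Compound 3 `CCCCC#Cc1c(C)[nH]c2ccc(Cl)cc2c1=O` has not yet been measured. It is compound 2 with a single change: chloro in place of hydrogen on an aromatic carbon. Among the compounds with values here, no pair of measured compounds shows what a change of this kind does, so the data offer no direct guide. In this assay no step beyond the scatter is expected, with only a slight lean towards a lower number. The estimated change is a 1.3-fold lower number from compound 2 to compound 3 (0.10 log units; within the scatter). For compound 3 the expected value is 400 10^-6 cm/s, with an estimated range of 150 10^-6 cm/s to 800 10^-6 cm/s.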

Compound 3, apparent permeability: 171 10^-6 cm/s
Compound 3: middle estimate off by 2.3-fold (0.37 log units), on the high side; measured number inside the range.
By their numbers in this assay, from the lowest: compound 1; then compound 3; then compound 2.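

In this assay, within the data shown here, chloro in place of hydrogen on an aromatic carbon, at the carbon meta to a fused ring and para to a fused ring, gives a 2.9-fold lower number from compound 2 to compound 3 (0.47 log units; beyond the scatter) and so, unlike the earlier compounds, shows a step for this change that lies beyond the scatter. With chloro present on both compounds, hex-1-yn-1-yl in place of bromo on an aromatic carbon gives a 2.0-fold higher number from compound 1 to compound 3 (0.31 log units; beyond the scatter) as a second step beyond the scatter, so on this chloro-bearing core the alkynyl compound holds the higher number. No measurement shown here bears on the reason for either step.

The compounds shown leave open whether fluoro, methoxy or an amine at this same carbon would shift the number in the same direction as chloro. They also leave open whether the chloro step would keep its size if a longer chain stood in place of hex-1-yn-1-yl.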